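Bromophenyl for methylphenyl on a shared oxadiazole-amine scaffold

The compounds below may be only part of what the source reports. "The series", "measured", "known", "first", "only" and "open" are said of these compounds alone.

Compound 1 `CC(=O)OC[C@H]1O[C@H](OC[C@@H](Cn2cc(CN(c3nc(-c4cccc(C)c4)no3)C3CCCCC3)nn2)OC(C)=O)C=C[C@@H]1OC(C)=O` and compound 2 `CC(=O)OC[C@H]1O[C@H](OC[C@@H](Cn2cc(CN(c3nc(-c4ccc(Br)cc4)no3)C3CCCCC3)nn2)OC(C)=O)C=C[C@@H]1OC(C)=O` carry a glycoside-triazole arm; compound 3 `C#CCN(c1nc(-c2cccc(C)c2)no1)C1CCCCC1` and compound 4 `C#CCN(c1nc(-c2ccc(Br)cc2)no1)C1CCCCC1` carry a propargyl group instead. How the core of compound 1 differs from that of compound 3 is not broken down here. In an ADME assay on HepG2 cells (Homo sapiens) for cytotoxicity, read by MTT assay, with a stated time of 48 h (a lower number here means that less compound is tolerated, a higher number that more compound is tolerated), compound 1 gives 39.2 ug/mL and compound 2 gives 47.6 ug/mL; the change 4-bromophenyl in place of 3-methylphenyl on an aromatic carbon made the step of a 1.2-fold higher number from compound 1 to compound 2 (0.08 log units; within the scatter). In this assay compound 3 gives 44.4 ug/mL. The same change, (4-bromophenyl in place of 3-methylphenyl on an aromatic carbon), now leads to compound 4. Because the step of a 1.2-fold higher number from compound 1 to compound 2 (0.08 log units; within the scatter) stayed within the scatter, a similarly small step is expected, a 1.1-fold higher number from compound 3 to compound 4 (0.05 log units; within the scatter). For compound 4 a value of 50 ug/mL is estimated, spanning 30 ug/mL to 80 ug/mL.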

Compound 4, half-maximal cytotoxic concentration: 102 ug/mL
The estimate for compound 4 lay 2.0-fold (0.31 log units) below the measured number, and the stated range ends below it.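

In this assay the change to 4-bromophenyl from 3-methylphenyl gives a 2.3-fold higher number from compound 3 to compound 4 (0.36 log units; beyond the scatter) on the propargyl compounds, and this step is not set apart from the earlier one on the glycoside-triazole compounds: the same change on two cores in this assay, a 1.2-fold higher number (0.08 log units; within the scatter) from compound 1 to compound 2 and a 2.3-fold higher number (0.36 log units; beyond the scatter) from compound 3 to compound 4, 1.9-fold (0.28 log units) apart, within the scatter of two such steps

So the change can be read as carrying over between these two cores with no shown difference, although only the step on the propargyl compounds passes beyond the scatter. Two pairs do not show that the step has one fixed size, or that it would hold on any other core. The compounds shown leave open whether the bromine atom itself or its place on the phenyl ring goes with the step. Going by these compounds, whether a chlorophenyl group, an aminophenyl group or a phenyl ring bearing a carboxylic acid would behave alike on both cores also stays open.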